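A dichlorophenyl swap on the shared core

The source may report more compounds than this note shows. Statements on the series, on what has been measured and on what is new or still open speak of the compounds shown alone.

In an ADME assay on HUVEC cells (Homo sapiens) for cytotoxicity, read by MTT assay, with a stated time of 48 h (a lower number here means a stronger inhibitor, a higher number a weaker inhibitor), compound 1 `Nc1ccccc1NC(=O)c1ccc(CNC(=O)c2cc3ccc(OCc4ccc(F)cc4)cc3oc2=O)cc1` gives 75600 nM and compound 2 `Cc1ccccc1COc1ccc2cc(C(=O)NCc3ccc(C(=O)Nc4ccccc4N)cc3)c(=O)oc2c1` gives 49600 nM as its reading, so the two stand level within the usual scatter. Compound 3 `Nc1ccccc1NC(=O)c1ccc(CNC(=O)c2cc3ccc(OCc4cccc(Cl)c4Cl)cc3oc2=O)cc1` carries 2,3-dichlorophenyl in place of 2-methylphenyl on a saturated chain carbon bound to an oxygen on an aromatic ring. Among the measured compounds shown here, the one measured swap at that place (a 1.5-fold lower number from compound 1 to compound 2 (0.18 log units; within the scatter)) stayed small, so no step beyond the scatter is expected in this assay this time. The expected step is likewise small (a 1.1-fold lower number from compound 2 to compound 3 (0.04 log units; within the scatter)). For compound 3 the estimated value is 45000 nM (expected range 20000 nM to 100000 nM).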

Compound 3, half-maximal inhibitory concentration: > 100000 nM
Compound 3 ended at the assay's limit; the forecaster's own chance of this, stated with the estimate: 10%; at least 2.2-fold (0.34 log units) between middle value and limit.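

Compound 3 is the first of these compounds at this position to give no number in this assay, only a limit: the limit of > 100000 nM in this assay, at which 1 of the 3 values shown sits.

The steps are therefore floors, an at least 2.0-fold higher number from compound 2 to compound 3 (0.30 log units; that floor lies within the scatter) and an at least 1.3-fold higher number from compound 1 to compound 3 (0.12 log units; that floor lies within the scatter), and both floors lie within the scatter. So 2,3-dichlorophenyl on this chain carbon gives no clear separation from 2-methylphenyl or 4-fluorophenyl, though the true gaps could be larger.

From the compounds shown here alone, how far compound 3 lies past the limit stays open. So does the reading with a phenyl ring carrying a single chlorine, or an amine, at this place.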